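Notes on the chain change from compound 2 to compound 3

The compounds below may be only part of what the source reports. "The series", "measured", "known", "first", "only" and "open" are said of these compounds alone.

Measured so far:
compound 1, `CCCCC/C=C\C/C=C\CCCCCCCc1cc(=O)c2c(O)cc(O)c(C)c2o1`: 17500 nM
compound 2, `CCCC/C=C\CCCCCCCCCc1cc(=O)c2c(O)c(C)c(O)c(C)c2o1`: > 67200 nM

In a functional assay on MCF7 cells (Homo sapiens) for antiproliferative activity, read by MTT assay (on this read-out lower numbers stand for stronger inhibition and higher numbers for weaker inhibition), compound 1 gives 17500 nM. For compound 2 the result is only a limit of the assay, > 67200 nM, so no number is known for it. Compound 2 therefore sits at the limit of > 67200 nM in this assay, at which 1 of the 2 values shown sits. Compound 3, `CCCCC/C=C\C/C=C\CCCCCCCc1cc(=O)c2c(O)c(C)c(O)c(C)c2o1`, is not yet measured. It differs from compound 2 in one place: deca-1,4-dien-1-yl in place of oct-3-en-1-yl on a saturated chain carbon, seven bonds along the chain from an aromatic carbon. Compound 1 already carries deca-1,4-dien-1-yl and gives a number where compound 2 gives only a limit, so some movement toward stronger inhibition is expected from the chain, of uncertain size. The expected step is an at least 1.6-fold lower number from compound 2 to compound 3 (0.22 log units; that floor lies within the scatter), toward stronger inhibition, and it may still leave compound 3 near the limit. For compound 3 the estimate is 40000 nM, within a range from 15000 nM to 100000 nM.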

Compound 3, half-maximal inhibitory concentration: > 84100 nM
Compound 3 gave a limit, no number; the forecaster's own chance of this, stated with the estimate: 45%; middle value at least 2.1-fold (0.32 log units) from the limit.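

In this assay, carrying deca-1,4-dien-1-yl does not by itself give a number on the core of compound 2: compound 3 also gives only a limit, > 84100 nM. The chain change, on a saturated chain carbon, seven bonds along the chain from an aromatic carbon, therefore cannot be read in size or direction, as both of its ends are limits. The readable change is instead methyl in place of hydrogen on an aromatic carbon, with an at least 4.8-fold higher number from compound 1 to compound 3 (0.68 log units; beyond the scatter), which on this read-out means weaker inhibition.

Going by these compounds, it remains open how the two chains compare when the extra methyl is present, and whether methyl in place of hydrogen gives a like step with oct-3-en-1-yl. On these data alone, it is also open whether a shorter chain or a carboxylic acid in place of deca-1,4-dien-1-yl would give a number rather than a limit on the core of compound 3.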